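Replacing the 2,6-dioxopiperidin-3-yl group with an open-chain acid

This account rests on a few compounds, and the source may have more. Where it says the series, first, only, none or still open, it means among the compounds named here.

Compound 1 `O=C1CCC(N2C(=O)C(c3ccccc3)=C(c3ccccc3)C2=O)C(=O)N1`: in an ADME assay on HUVEC cells (Homo sapiens) for cytotoxicity, read by MTT assay (a higher number here means a weaker inhibitor, a lower number a stronger inhibitor), compound 1 gives > 50000 nM, which is a limit of the assay, not a number.
Compound 2 `CN(C)CCN1C(=O)CCC(N2C(=O)C(c3ccccc3)=C(c3ccccc3)C2=O)C1=O`: in this assay compound 2 gives > 50000 nM, again a limit.

Compound 1 therefore stands only at a limit in this assay, with no measured number of its own. Within the data shown here, the single measured step, a step that the two limits leave unreadable from compound 1 to compound 2, cannot be read, because of the limit of > 50000 nM in this assay, at which 2 of the 2 values shown sit. Compound 3 `NC(=O)CCC(C(=O)O)N1C(=O)C(c2ccccc2)=C(c2ccccc2)C1=O` is the ring-opened relative: 3-carbamoyl-1-carboxypropyl in place of 2,6-dioxopiperidin-3-yl on an amide-type nitrogen in a ring. Among the measured compounds shown here, no measured step bears on this change in a readable way, so no direction of movement beyond the scatter can be expected; the most that can be said is that compound 3 is expected to sit where compound 1 already sits, at the limit. Compound 3 is thus estimated at 100000 nM, with a range from 30000 nM to 300000 nM. The expected step is a step that the limit leaves unreadable from compound 1 to compound 3.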

Compound 3, half-maximal inhibitory concentration: > 50000 nM
Compound 3: a limit, no number; the forecaster's own chance of this, stated with the estimate: 85%; the middle value lies beyond the limit too.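

Compound 3, like compound 1, gives only a limit, so the change from compound 1 to compound 3 cannot be read, because no number exists on either side: the limit of > 50000 nM in this assay, at which 3 of the 3 values shown sit.

The compounds shown leave open whether replacing 2,6-dioxopiperidin-3-yl with 3-carbamoyl-1-carboxypropyl changes anything in this assay at all.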